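A few compounds are considered here, and "the series" means these few. Any claim that something is new, unique, unknown or untested is made for them only; others in the source may bear on it.

Compounds measured in a functional assay on HepG2 cells (Homo sapiens) for inhibition, read by XTT assay, with a stated time of 72 h; on this read-out higher numbers stand for weaker inhibition and lower numbers for stronger inhibition:
Compound 1 `CC(=O)N(c1nc(CCl)cs1)N(C(C)=O)S(=O)(=O)c1ccc(C)cc1`; its value is a limit of the assay, > 62300 nM.
Compound 2 `CC(=O)c1sc(N(C(C)=O)N(C(C)=O)S(=O)(=O)c2ccc(C)cc2)nc1C`; it gives 57400 nM.
Compound 3 `CCOC(=O)c1sc(N(C(C)=O)N(C(C)=O)S(=O)(=O)c2ccc(C)cc2)nc1C`; its value is a limit of the assay, > 56900 nM.

Compound 1 stands only at a limit in this assay, and one further value shown, that of compound 3, is likewise a limit (the limit of > 62300 nM in this assay, at which 1 of the 3 values shown sits, (the limit of > 56900 nM in this assay, at which 1 of the 3 values shown sits)). Compound 4 `CCOC(=O)Cc1csc(N(C(C)=O)N(C(C)=O)S(=O)(=O)c2ccc(C)cc2)n1` differs from compound 1 by ethoxycarbonyl in place of chloro on a saturated chain carbon bound to an aromatic carbon, which, cut one bond further out, reads chloromethyl to (ethoxycarbonyl)methyl. The measured steps that bear on this change are an at least 1.0-fold lower number from compound 1 to compound 2 (0.03 log units; that floor lies within the scatter) and a step that the limit leaves unreadable from compound 2 to compound 3. Neither shows a readable change beyond the scatter, and all three measured values sit at or near the limits of the assay. He therefore expects no step beyond the scatter in this assay, with a fair chance that compound 4 again gives only a limit. His estimate for compound 4 is 60000 nM, between 30000 nM and 120000 nM. The step he expects, an at least 1.0-fold lower number from compound 1 to compound 4 (0.01 log units; that floor lies within the scatter), lies within the scatter.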

Compound 4, half-maximal inhibitory concentration: 11000 nM
The estimate for compound 4 lay 5.5-fold (0.74 log units) above the measured number; measured number outside the range, below it.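

In this assay, the saturated chain carbon bound to an aromatic carbon proves to be a place where a change can be read: ethoxycarbonyl in place of chloro brings an at least 5.6-fold lower number from compound 1 to compound 4 (0.75 log units; beyond the scatter). None of the earlier steps had shown a readable change beyond the scatter, and this one is the first among the compounds shown to do so. Compound 1 stands only at a limit, which makes this step a floor and leaves its full size unknown: the limit of > 62300 nM in this assay, at which 1 of the 4 values shown sits.

The compounds shown leave open whether the gain comes from the ester itself or from the departure of chloro, which a plain methyl, a carboxylic acid or an amine on that carbon would help to separate. They also leave open whether a longer chain carrying the ethoxycarbonyl would go further or lose the gain.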